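The compounds below may be only part of what the source reports. "The series", "measured", "known", "first", "only" and "open" are said of these compounds alone.

Values in a functional assay on HCT-116 cells (Homo sapiens) for inhibition; a lower number here means a stronger inhibitor, a higher number a weaker inhibitor:
- compound 1 `CN1CCC(c2c(O)cc(O)c3c2O/C(=C\c2ccccc2)C3=O)CC1`: > 50000 nM, a limit
- compound 2 `CN1CCC(c2c(O)cc(O)c3c2O/C(=C\c2ccccc2Cl)C3=O)CC1`: 20100 nM

For the measured compounds named here, compound 2 holds the only true number so far, as the other entry is a limit. Compound 3 `CN1CCC(c2c(O)cc(O)c3c2O/C(=C\c2ccc([N+](=O)[O-])cc2)C3=O)CC1` carries 4-nitrophenyl in place of 2-chlorophenyl on a double-bonded chain carbon bound to a double-bonded ring carbon. Going by the values given here, the one measured step, an at least 2.4-fold lower number from compound 1 to compound 2 (0.39 log units; beyond the scatter), is modest and only indirectly relevant, as chloro replaces hydrogen on an aromatic carbon. No change beyond the scatter is therefore expected in this assay, with a slight lean towards weaker inhibition. The estimated step is a 1.2-fold higher number from compound 2 to compound 3 (0.09 log units; within the scatter). The expected value for compound 3 is 25000 nM, within an estimated range of 8000 nM to 60000 nM.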

Compound 3, half-maximal inhibitory concentration: 35600 nM
Compound 3: middle estimate off by 1.4-fold (0.15 log units), on the low side; measured number inside the range.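

In this assay, 4-nitrophenyl and 2-chlorophenyl on a double-bonded chain carbon bound to a double-bonded ring carbon are not told apart: a 1.8-fold higher number from compound 2 to compound 3 (0.25 log units; within the scatter). Where the only change is an added nitro group, the series shows an at least 1.4-fold lower number from compound 1 to compound 3 (0.14 log units; that floor lies within the scatter), so this pair gives only a floor. Compound 1 is a limit: the limit of > 50000 nM in this assay, at which 1 of the 3 values shown sits.

The two substituted rings differ in both the group and where it sits, and these two factors remain unseparated. On these data alone, whether 4-chlorophenyl, 4-aminophenyl or 4-carboxyphenyl at this place would move the number beyond the scatter stays open.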